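This account rests on a few compounds, and the source may have more. Where it says the series, first, only, none or still open, it means among the compounds named here.

Values so far in an ADME assay on microsomes from liver (Rattus norvegicus) for metabolic stability; on this read-out higher numbers stand for a longer-lived compound and lower numbers for a shorter-lived compound

compound 1 `CC(C)C(c1ncco1)c1ccc(-c2ccc3cccc(F)c3c2)[nH]c1=O` gives 0.0983 h
compound 2 `CC(C)C(Cc1nnc[nH]1)c1ccc(-c2ccc3cccc(F)c3c2)[nH]c1=O` gives 0.1 h
compound 3 `CC(C)C(c1ccc(-c2ccc3cccc(F)c3c2)[nH]c1=O)N1CCN/C1=N\C#N` gives 0.327 h

Compound 3 (0.327 h) stands highest of the three, beyond the scatter from both of the others. Compound 4 `CC(C)C(Nc1nccs1)c1ccc(-c2ccc3cccc(F)c3c2)[nH]c1=O` brings this change (a group of 6 heavy atoms (3 carbon, 2 nitrogen, 1 sulfur; one five-membered aromatic ring with 2 hetero atoms) in place of a group of 8 heavy atoms (4 carbon, 4 nitrogen; one five-membered non-aromatic ring with 2 hetero atoms), on a saturated chain carbon bound to an aromatic carbon and a saturated chain carbon).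

For the measured compounds named here, two measured steps bear most directly on it (a 3.3-fold higher number from compound 1 to compound 3 (0.52 log units; beyond the scatter); a 3.3-fold higher number from compound 2 to compound 3 (0.51 log units; beyond the scatter)). Both are modest, and in both the non-aromatic ring group enters in place of a five-membered aromatic ring. Compound 4 runs that exchange the other way, again ending on a five-membered aromatic ring. The two aromatic groups measured so far do not separate (a 1.0-fold higher number from compound 1 to compound 2 (0.01 log units; within the scatter)), so the entering group is expected to fall near them. Going by the values given here, this rests on three compounds only, none of which goes against it, and no measured compound carries the (1,3-thiazol-2-yl)amino group.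

A modest step to a lower number in this assay, beyond the scatter and about the size of those two steps read in reverse, is therefore expected. The estimated change is this (a 3.0-fold lower number from compound 3 to compound 4 (0.47 log units; beyond the scatter)). For compound 4 the estimated value is (0.11 h), with an expected range of (0.05 h to 0.25 h).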

Compound 4, half-life: 0.07 h
The estimate for compound 4 lay 1.6-fold (0.20 log units) above the measured number, within the range that was stated.
By their numbers in this assay, from the lowest: compounds 4, 1 and 2 (each within the scatter of the next); then compound 3.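

In this assay, putting (1,3-thiazol-2-yl)amino in place of the non-aromatic ring group gives a 4.7-fold lower number from compound 3 to compound 4 (0.67 log units; beyond the scatter), so the exchange now holds for a third five-membered aromatic ring group, this one with sulfur in the ring and an amino link to the saturated chain carbon. This group does not separate from the two earlier aromatic groups, as a 1.4-fold lower number from compound 2 to compound 4 (0.15 log units; within the scatter) and a 1.4-fold lower number from compound 1 to compound 4 (0.15 log units; within the scatter) both lie within the scatter, and so neither the change of ring hetero atoms nor the change among a direct bond, a methyl link and an amino link moves the number beyond the scatter in this set. Compound 3 alone stands apart from compound 1, compound 2 and compound 4 at this position, and nothing at hand gives a reason for that gap.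

Whether the higher number of compound 3 goes with the non-aromatic ring itself or with its nitrile stays open among the compounds shown. Also open, from the compounds shown here alone, is how a simple amine, a carboxylic acid or a morpholine ring would read on the same saturated chain carbon.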